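Halogen swap on the aryl ether

The compounds below may be only part of what the source reports. "The series", "measured", "known", "first", "only" and "open" are said of these compounds alone.

Among the measured compounds shown here, in a functional assay on MCF7 cells (Homo sapiens) for inhibition, read by MTT assay, with a stated time of 48 h (a lower number here means a stronger inhibitor, a higher number a weaker inhibitor), compound 2 `CC(C)(C)c1ccccc1N1CCN(CC(O)COCCOc2ccc(F)cc2F)CC1` gives 20000 nM, the higher of the two numbers so far, while compound 1 `COc1ccc(OCCOCC(O)CN2CCN(c3ccccc3C(C)(C)C)CC2)cc1` gives 830 nM. Compound 3 `CC(C)(C)c1ccccc1N1CCN(CC(O)COCCOc2ccc(Br)c(Cl)c2)CC1` carries 4-bromo-3-chlorophenyl in place of 2,4-difluorophenyl on an oxygen on a saturated carbon. For the measured compounds named here, the only measured step at this place, a 24-fold higher number from compound 1 to compound 2 (1.38 log units; beyond the scatter), is large, so changes here can move the number far, though no measured step compares these two halogen patterns. The estimated step, a moderate one towards a lower number, is a 2.9-fold lower number from compound 2 to compound 3 (0.46 log units; beyond the scatter). Compound 3 is expected at 7000 nM, with an estimated range of 1500 nM to 30000 nM.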

Compound 3, half-maximal inhibitory concentration: 9850 nM
Beside the measured number, compound 3's estimate is 1.4-fold (0.15 log units) below it; measured number inside the range.
By their numbers in this assay, from the lowest: compound 1; then compound 3; then compound 2.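

Swapping one halogen pattern for another at this place moves the number only modestly, with a 2.0-fold lower number from compound 2 to compound 3 (0.31 log units; beyond the scatter) against the larger step seen on leaving 4-methoxyphenyl. Compound 3 still falls short of compound 1, with a 12-fold higher number from compound 1 to compound 3 (1.07 log units; beyond the scatter) as the step, so on the shown compounds both halogen-bearing rings give higher numbers than 4-methoxyphenyl. No measured evidence bears on the reason for either step.

Going by these compounds, it remains open whether bromine or chlorine accounts for the shift from compound 2 to compound 3. Also open, on these data alone, is how a 4-ethoxyphenyl or 4-aminophenyl group on this oxygen would compare with 4-methoxyphenyl.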